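Fluoro for methyl on the sulfonamide aryl ring

This account rests on a few compounds, and the source may have more. Where it says the series, first, only, none or still open, it means among the compounds named here.

Of the compounds shown here, three sharing one core have been measured in an assay on MDA-MB-231 cells for binding affinity to C-X-C chemokine receptor type 4 (Homo sapiens), read by fluorescence and microscopy, with stated times of 10 min and 30 min; on this read-out higher numbers stand for an effect only at larger amounts of compound and lower numbers for an effect already at smaller amounts. Compound 1 `O=C(NCc1ccc(CNS(=O)(=O)c2cccc(C(F)(F)F)c2)cc1)c1ccc(F)cc1` gives 100 nM in this assay. Compound 2 `O=C(NCc1ccc(CNS(=O)(=O)c2ccc([N+](=O)[O-])cc2)cc1)c1ccc(F)cc1` gives 1000 nM in this assay, and the step of a 10-fold higher number from compound 1 to compound 2 (1.00 log units; beyond the scatter) is the only one among them that goes beyond the scatter. Compound 3 `Cc1ccccc1S(=O)(=O)NCc1ccc(CNC(=O)c2ccc(F)cc2)cc1` gives 100 nM in this assay; it stands level with compound 1, the two together the lowest of the three numbers, while no change at the digits printed from compound 1 to compound 3 (within the scatter) and a 10-fold lower number from compound 2 to compound 3 (1.00 log units; beyond the scatter) describe its position.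

Compound 4 `O=C(NCc1ccc(CNS(=O)(=O)c2ccccc2F)cc1)c1ccc(F)cc1` is not yet measured. It differs from compound 3 by fluoro in place of methyl on an aromatic carbon, so that the 2-methylphenyl on the sulfonyl sulfur becomes a 2-fluorophenyl, the new group sitting on an aromatic carbon of a six-membered aromatic ring of carbon only, ortho to a large group.

For the measured compounds named here, no measured step exchanges a methyl for a fluoro, so the bearing steps are indirect: no change at the digits printed from compound 1 to compound 3 (within the scatter) shows that one change of substituent on this ring left the number unmoved, whereas a 10-fold higher number from compound 1 to compound 2 (1.00 log units; beyond the scatter) shows that another moved it modestly. On that basis the step of a 1.5-fold higher number from compound 3 to compound 4 (0.18 log units; within the scatter) is expected to stay within the scatter. Compound 4 is therefore estimated at 150 nM in this assay, in the range 50 nM to 500 nM.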

Compound 4, effective concentration (reported as EC, without a stated level of effect): 10 nM
For compound 4 the middle estimate is 15-fold (1.18 log units) above the measured one; the whole stated range lies above it.
By their numbers in this assay, from the lowest: compound 4; then compounds 1 and 3 (each within the scatter of the next); then compound 2.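

In this assay, fluoro in place of methyl on an aromatic carbon, ortho to a large group, gives a 10-fold lower number from compound 3 to compound 4 (1.00 log units; beyond the scatter). For the compounds shown here, this is the first measured change on the sulfonamide aryl ring to take a number below the level shared by compound 1 and compound 3, and it shows that exchanging one heavy atom at this place can move the result beyond the scatter. The 2-fluorophenyl also sets compound 4 apart from the other two compounds, with a 10-fold lower number from compound 1 to compound 4 (1.00 log units; beyond the scatter) and the large 100-fold lower number from compound 2 to compound 4 (2.00 log units; beyond the scatter), so compound 4 now has the lowest number of the four, although nothing shown here accounts for the effect of the exchange.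

Whether this gain belongs to fluoro itself or would also appear with another small group on the same carbon stays open, as the compounds shown include neither a chloro nor a methoxy group there, nor a plain phenyl ring on the sulfonyl sulfur. Going by these compounds, it is also open whether a second fluoro on this ring would lower the number further or raise it again.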